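Swapping the aryl group of compound 3 for a dimethylisoxazole

A few compounds are considered here, and "the series" means these few. Any claim that something is new, unique, unknown or untested is made for them only; others in the source may bear on it.

Compound 1 `Cc1nn(-c2ncnc3nc[nH]c23)c2c1C(OCC(=O)c1ccc(F)cc1)CC(=O)N2` gives 3 nM in a functional assay on HEK293 cells for agonist activity at G-protein coupled receptor 39 (Homo sapiens), read by scintillation proximity assay and inositol phosphate accumulation, with a stated time of 75 min, in the presence of a further agent that is not named here; a lower number here means that less compound is needed, a higher number that more compound is needed for the effect.
Compound 2 `Cc1nn(-c2ncnc3nc[nH]c23)c2c1C(OCc1ccccc1F)CC(=O)N2` gives 4 nM in this assay.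
Compound 3 `Cc1nn(-c2ncnc3nc[nH]c23)c2c1C(OCc1ccc(C(C)C)cc1)CC(=O)N2` gives 5 nM in this assay.

Compound 3 has the highest of the three numbers, yet its nearest neighbour is compound 2 with a 1.3-fold higher number from compound 2 to compound 3 (0.10 log units; within the scatter) and the furthest is compound 1 with a 1.7-fold higher number from compound 1 to compound 3 (0.22 log units; within the scatter), both within the scatter, so the three compounds cannot be ranked against one another.

Compound 4 `Cc1noc(C)c1COC1CC(=O)Nc2c1c(C)nn2-c1ncnc2nc[nH]c12` differs from compound 3 by 3,5-dimethyl-1,2-oxazol-4-yl in place of 4-isopropylphenyl on a saturated chain carbon bound to an oxygen on a saturated carbon. The measured steps that bear on this change are the three exchanges at the same place: a 1.3-fold higher number from compound 1 to compound 2 (0.12 log units; within the scatter), a 1.7-fold higher number from compound 1 to compound 3 (0.22 log units; within the scatter) and a 1.3-fold higher number from compound 2 to compound 3 (0.10 log units; within the scatter). Each of them replaced one group on that chain carbon by another and each stayed within the scatter. Among the measured compounds shown here, none of the measured exchanges brought in a heteroaromatic ring, so the step to compound 4 reaches somewhat beyond what the three compounds cover; even so, nothing in the measured record points to a step beyond the scatter in this assay.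

Compound 4 is therefore expected to give about 6 nM in this assay, with a range from 2 nM to 20 nM. The expected step is a 1.2-fold higher number from compound 3 to compound 4 (0.08 log units; within the scatter), which is estimated to remain within the scatter.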

Compound 4, half-maximal effective concentration: 5 nM
Compound 4: middle estimate off by 1.2-fold (0.08 log units), on the high side; measured number inside the range.
By their numbers in this assay, from the lowest: compounds 1, 2, 3 and 4 (each within the scatter of the next).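

Among the compounds shown here, the 3,5-dimethyl-1,2-oxazol-4-yl group is the first heteroaromatic ring at this place, and in this assay its exchange for 4-isopropylphenyl gives no change at the digits printed from compound 3 to compound 4 (within the scatter), even though the entering group brings a five-membered aromatic ring with 2 hetero atoms and 2 hydrogen-bond acceptors in place of a six-membered ring of carbon only with none. The comparisons with the other two groups agree, with a 1.3-fold higher number from compound 2 to compound 4 (0.10 log units; within the scatter) and a 1.7-fold higher number from compound 1 to compound 4 (0.22 log units; within the scatter), so the range of groups on this saturated chain carbon that stay within the scatter of one another now extends from carbon-only aromatic rings to a ring holding nitrogen and oxygen. Nothing measured here says why the numbers stay level across these groups.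

All four groups carry an aromatic ring, so the compounds shown leave open whether the same level would hold for an amine, a carboxylic acid or a plain saturated alkyl chain at this place. They also leave open what the two methyl groups contribute, which the unsubstituted 1,2-oxazol-4-yl ring would show.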